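A few compounds are considered here, and "the series" means these few. Any claim that something is new, unique, unknown or untested is made for them only; others in the source may bear on it.

Measured compounds:
compound 1, `CN(C)c1ccc(C(=O)Nc2cccc(NC(=O)COc3ccc4occc(=O)c4c3)c2)cc1`: > 10000 nM
compound 2, `O=C(COc1ccc2c(=O)ccoc2c1)Nc1cccc(NC(=O)c2ccccc2)c1`: 16 nM

For the measured compounds named here, in an assay on isolated protein for inhibition of Rho-associated protein kinase 2 (Homo sapiens), read by scintillation counting, radiometric assay and 33P incorporation, with a stated time of 40 min, in the presence of a further agent that is not named here (a higher number here means a weaker inhibitor, a lower number a stronger inhibitor), compound 2 gives 16 nM, the only number in the set. For compound 1 the value > 10000 nM is a limit of the assay, not a number (the limit of > 10000 nM in this assay, at which 1 of the 2 values shown sits). Going by the values given here, no step between the measured pair is given; the two values show only that compound 1 sits at the limit and compound 2 does not. Compound 3, `COC(=O)c1ccc(C(=O)Nc2cccc(NC(=O)COc3ccc4c(=O)ccoc4c3)c2)cc1`, is not yet measured and differs from compound 2 by methoxycarbonyl in place of hydrogen on an aromatic carbon. Since compound 1, which also carries a substituent on a six-membered aromatic ring of carbon only, para to a large group, sits at the limit (the limit of > 10000 nM in this assay, at which 1 of the 2 values shown sits), a sizeable loss is expected from compound 2 to compound 3, a 31-fold higher number from compound 2 to compound 3 (1.49 log units; beyond the scatter). Compound 3 is estimated at 500 nM, between 50 nM and 10000 nM.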

Compound 3, half-maximal inhibitory concentration: 29 nM
For compound 3 the middle estimate is 17-fold (1.24 log units) above the measured one; measured number outside the range, below it.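

Methoxycarbonyl on this aromatic carbon, para to a large group, costs nothing that can be told from the scatter: a 1.8-fold higher number from compound 2 to compound 3 (0.26 log units; within the scatter). Compound 1 gives > 10000 nM, a limit of the assay and not a number, and it differs from compound 2 in more than one place, so it says little about this position alone. Nothing shown gives a cause for this result.

Open, from the compounds shown here alone, is whether a carboxylic acid or an amine at this position behaves like methoxycarbonyl. Also open, going by these compounds, is what dimethylamino does here on the core of compound 2.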